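From benzyl to 4-chlorobenzyl: a small step expected

A few compounds are considered here, and "the series" means these few. Any claim that something is new, unique, unknown or untested is made for them only; others in the source may bear on it.

compound 1 `COc1cc(CN(C(=O)CSc2nc3ccccc3s2)c2cc(OC)c(OC)c(OC)c2)cc(OC)c1OC`: 65300 nM
compound 2 `COc1cc(N(Cc2ccccc2)C(=O)CSc2nc3ccccc3s2)cc(OC)c1OC`: 54500 nM

Both values come from a functional assay on HCT-116 cells (Homo sapiens) for antiproliferative activity, read by MTT assay, with a stated time of 48 h; a higher number here means a weaker inhibitor, a lower number a stronger inhibitor. Compound 2, at 54500 nM, cannot be told apart from compound 1, at 65300 nM, since the two lie within the usual scatter. Compound 3 `COc1cc(N(Cc2ccc(Cl)cc2)C(=O)CSc2nc3ccccc3s2)cc(OC)c1OC` keeps everything in compound 2 except one spot: chloro in place of hydrogen on an aromatic carbon. This is chloro in place of hydrogen on an aromatic carbon, which turns benzyl into 4-chlorobenzyl.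

Going by the values given here, only one measured step offers any guide: a 1.2-fold lower number from compound 1 to compound 2 (0.08 log units; within the scatter). It also alters that aromatic group, yet it stayed within the scatter. Among the compounds with values here, no chloro compound has been measured, so the guide is weak. A similarly small step in this assay is expected, leaning only slightly towards a lower number.

The estimated step is a 1.3-fold lower number from compound 2 to compound 3 (0.11 log units; within the scatter). For compound 3 the expected value is 42000 nM, with an estimated range of 17000 nM to 85000 nM.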

Compound 3, half-maximal inhibitory concentration: 603000 nM
Beside the measured number, compound 3's estimate is 14-fold (1.16 log units) below it, and the stated range ends below it.
By their numbers in this assay, from the lowest: compounds 2 and 1 (each within the scatter of the next); then compound 3.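

In this assay, this aromatic group proves sensitive to one added atom: there is an 11-fold higher number from compound 2 to compound 3 (1.04 log units; beyond the scatter) when chloro replaces hydrogen para to a large group, although the change from 3,4,5-trimethoxyphenyl to phenyl stayed within the scatter. Set against the 3,4,5-trimethoxyphenyl compound, there is also a 9.2-fold higher number from compound 1 to compound 3 (0.97 log units; beyond the scatter) with 4-chlorophenyl in its place, so compound 3 stands apart as the weakest of the three. Nothing measured here explains this drop.

The compounds shown leave open whether the drop is particular to chloro or would also appear with fluoro, methyl or an amine on the same carbon. They also leave open whether chloro elsewhere on that six-membered ring would give a similar number.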